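Series notes: chloro for methoxy, compound 1 to compound 4

A few compounds are considered here, and "the series" means these few. Any claim that something is new, unique, unknown or untested is made for them only; others in the source may bear on it.

Measured so far:
compound 1 `COc1ccc(/C=C/S(=O)(=O)Cc2ccc(OC)cc2)cc1` — > 20000 nM
compound 2 `COc1cc(OC)c(/C=C/S(=O)(=O)Cc2ccc(Cl)cc2)c(OC)c1` — 10000 nM
compound 3 `COc1cc(OC)c(/C=C/S(=O)(=O)Cc2ccc(C(=O)O)cc2)c(OC)c1` — 15000 nM

In a functional assay on BT-20 cells (Homo sapiens) for antiproliferative activity, read by trypan blue exclusion (a lower number here means a stronger inhibitor, a higher number a weaker inhibitor), compound 1 gives only a limit, > 20000 nM (the limit of > 20000 nM in this assay, at which 1 of the 3 values shown sits). Going by the values given here, compound 2 gives 10000 nM and compound 3 gives 15000 nM; the single measured step is a 1.5-fold higher number from compound 2 to compound 3 (0.18 log units; within the scatter). Compound 4 `COc1ccc(CS(=O)(=O)/C=C/c2ccc(Cl)cc2)cc1` differs from compound 1 by chloro in place of methoxy on an aromatic carbon. The measured step concerns a different site and a different substituent pair, so it bears on this change only loosely; it shows one aryl substituent swap in this series leaving this assay within the scatter. No step beyond the scatter is therefore expected. Compound 4 is estimated at 20000 nM, range 8000 nM to 50000 nM, an expected step of a number no higher from compound 1 to compound 4 (the limit leaves the size open), with a limit rather than a number remaining likely.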

Compound 4, half-maximal inhibitory concentration: 2000 nM
The estimate for compound 4 lay 10-fold (1.00 log units) above the measured number, and the stated range ends above it.
By their numbers in this assay, from the lowest: compound 4; then compounds 2 and 3 (each within the scatter of the next). At a limit, above all of these: compound 1.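

In this assay, an at least 10-fold lower number from compound 1 to compound 4 (1.00 log units; beyond the scatter). Going by these compounds alone, this is the first single-site swap to move beyond the scatter, so this aromatic carbon, unlike the site changed in the earlier step, is one where the substituent matters. The step rests on a limit for compound 1, and its full size stays open: the limit of > 20000 nM in this assay, at which 1 of the 4 values shown sits.

Still open, going by these compounds, is whether the gain follows from chloro entering or from methoxy leaving. Fluoro, bromo or an amine on this carbon would bear on that question.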